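This account rests on a few compounds, and the source may have more. Where it says the series, first, only, none or still open, it means among the compounds named here.

Compound 1 `CC1(C)CCCN(CCCCC2CCCc3ccccc32)C1` is the unsubstituted parent of this small set. Among the compounds with values here, in an assay on cell membranes for binding affinity to Sigma non-opioid intracellular receptor 1 (Rattus norvegicus), read by radioligand binding (a higher number here means a weaker inhibitor, a lower number a stronger inhibitor), compound 1 gives 0.69 nM, the lowest of the three numbers measured so far. Compound 2 `COc1cccc2c1CCCC2CCCCN1CCCC(C)(C)C1` gives 978 nM in this assay, and compound 3 `COc1ccc2c(c1)CCCC2CCCCN1CCCC(C)(C)C1` gives 2150 nM. Each of them differs from compound 1 by a methoxy in place of hydrogen on an aromatic carbon, and each step was large: a 1400-fold higher number from compound 1 to compound 2 (3.15 log units; beyond the scatter) and a 3100-fold higher number from compound 1 to compound 3 (3.49 log units; beyond the scatter). Compound 4 `COc1ccc2c(c1)C(CCCCN1CCCC(C)(C)C1)CCC2` has not yet been measured; it differs from compound 1 by methoxy in place of hydrogen on an aromatic carbon. It is thus the same kind of change, a methoxy group placed elsewhere on the aromatic ring. The two measured steps bear directly on it, and both were large increases in the number, so a large increase in this assay is the natural expectation, although nothing measured shows whether this third placement behaves like the other two. Compound 4 is therefore expected to give about 1500 nM in this assay, within roughly 250 nM to 9000 nM, which would mean an expected step of a 2200-fold higher number from compound 1 to compound 4 (3.34 log units; beyond the scatter).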

Compound 4, half-maximal inhibitory concentration: 25.6 nM
Compound 4: middle estimate off by 59-fold (1.77 log units), on the high side; the whole stated range lies above it.
By their numbers in this assay, from the lowest: compound 1; then compound 4; then compound 2; then compound 3.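

Methoxy in place of hydrogen still raises the number at this third placement, meta to a fused ring and para to a fused ring, with a 37-fold higher number from compound 1 to compound 4 (1.57 log units; beyond the scatter). So all three placements shown give a weaker binder than compound 1, but the size of the loss depends on where the group sits: a 1400-fold higher number from compound 1 to compound 2 (3.15 log units; beyond the scatter) and a 3100-fold higher number from compound 1 to compound 3 (3.49 log units; beyond the scatter) are much larger, so this one change on the same core carries no single fixed cost in this assay. Nothing available explains why this placement loses less than the other two.

The compounds shown leave open whether a hydroxyl group or a chlorine atom at this placement would stay as close to compound 1 as methoxy does. They also leave open whether the same pattern among placements would hold with a shorter chain to the amine.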